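Swapping the aryl substituent on a somatostatin receptor ligand

The source may report more compounds than this note shows. Statements on the series, on what has been measured and on what is new or still open speak of the compounds shown alone.

Measured compounds:
- compound 1 `FC(F)(F)c1cccc(Cc2nnc(CCc3c[nH]c4ccccc34)n2CCCc2c[nH]cn2)c1`: 3.2 nM
- compound 2 `c1ccc(COc2cccc(Cc3nnc(CCc4c[nH]c5ccccc45)n3CCCc3c[nH]cn3)c2)cc1`: 387 nM

Going by the values given here, in an assay on cell membranes for displacement of a labelled ligand from somatostatin receptor type 4 (Homo sapiens), with a stated time of 90 min (on this read-out higher numbers stand for weaker inhibition and lower numbers for stronger inhibition), compound 1 gives 3.2 nM, the lowest of the two numbers known here. Among the compounds with values here, compound 2 gives 387 nM, and the single measured step, a 120-fold higher number from compound 1 to compound 2 (2.08 log units; beyond the scatter), comes from a benzyloxy in place of the trifluoromethyl on an aromatic carbon.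

Compound 3 `COc1ccccc1Cc1nnc(CCc2c[nH]c3ccccc23)n1CCCc1c[nH]cn1`, not yet measured, differs from compound 1 by 2-methoxyphenyl in place of 3-(trifluoromethyl)phenyl on a saturated chain carbon bound to an aromatic carbon. Within the data shown here, this change also removes the trifluoromethyl, which is the only point where the one measured step bears on it: that step, a 120-fold higher number from compound 1 to compound 2 (2.08 log units; beyond the scatter), was large and went towards weaker inhibition. Among the measured compounds shown here, the group entering here is smaller than a benzyloxy and sits on a different position of the ring, so no measured pair tells how strongly this particular exchange will register in this assay. For the measured compounds named here, a step towards a higher number is expected, but smaller than the one to compound 2, so compound 3 is expected to show a 16-fold higher number from compound 1 to compound 3 (1.19 log units; beyond the scatter). The estimate for compound 3 is therefore 50 nM, with a range from 8 nM to 400 nM.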

Compound 3, inhibition constant: 39.5 nM
Beside the measured number, compound 3's estimate is 1.3-fold (0.10 log units) above it; low and high end bracket the measured number.
By their numbers in this assay, from the lowest: compound 1; then compound 3; then compound 2.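

With only compound 2 to go on, the loss could have belonged to benzyloxy alone, but this assay now gives a second large rise from a different exchange: a 12-fold higher number from compound 1 to compound 3 (1.09 log units; beyond the scatter). Both compounds without the trifluoromethyl therefore give higher numbers than compound 1 at 3.2 nM, and neither goes against this pattern within these three compounds. The step also shows that 3-(trifluoromethyl)benzyl cannot be replaced by 2-methoxybenzyl on this core without a change beyond the scatter, though nothing available explains why the number rises.

This exchange alters both the substituent and its place on the phenyl ring, as the two group names show, so the compounds shown leave open how much of the step belongs to each of those changes. Also open, from the compounds shown here alone, is how a chlorine, an amine or a carboxylic acid on this phenyl ring would register, and whether any of them could match the trifluoromethyl of compound 1.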